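This account rests on a few compounds, and the source may have more. Where it says the series, first, only, none or still open, it means among the compounds named here.

Measured so far in a functional assay on HepG2 cells (Homo sapiens) for antiproliferative activity, read by MTT assay, with a stated time of 48 h; a higher number here means a weaker inhibitor, a lower number a stronger inhibitor:

- compound 1 `COc1ccc(-c2ccc3c(c2)C(=O)C(=O)N3C)cc1`: 6670 nM
- compound 2 `CCN1C(=O)C(=O)c2cc(-c3ccc(OC)cc3)ccc21`: 4470 nM
- compound 3 `COc1ccc(-c2ccc3c(c2)C(=O)C(=O)N3Cc2cccc(Cl)c2)cc1`: 320 nM

Compound 3 has the lowest number of the three, which makes it the strongest inhibitor of this small set. Compound 4 `COc1ccc(-c2ccc3c(c2)C(=O)C(=O)N3Cc2ccccc2Cl)cc1` has the same atoms as compound 3, joined differently: 2-chlorophenyl in place of 3-chlorophenyl on a saturated chain carbon bound to an amide-type nitrogen in a ring. The measured steps at this place tell a clear story. There is a 1.5-fold lower number from compound 1 to compound 2 (0.17 log units; within the scatter), while the larger replacements give a 21-fold lower number from compound 1 to compound 3 (1.32 log units; beyond the scatter) and a 14-fold lower number from compound 2 to compound 3 (1.15 log units; beyond the scatter). Those last two steps show what a 3-chlorophenyl group brings compared with a smaller end to the chain, and compound 4 still carries a chlorophenyl group. Within the data shown here, no measured compound compares one chlorine placement with another, so the direction of this change remains open. A large loss or gain is therefore not expected, only a small drift that stays within the scatter. The expected change is a 1.3-fold higher number from compound 3 to compound 4 (0.13 log units; within the scatter). For compound 4 the estimate is 430 nM, with an expected range from 130 nM to 1400 nM.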

Compound 4, half-maximal inhibitory concentration: 600 nM
Estimate against measurement, compound 4: 1.4-fold (0.14 log units) below, and the stated range covers the measured number.
By their numbers in this assay, from the lowest: compounds 3 and 4 (each within the scatter of the next); then compounds 2 and 1 (each within the scatter of the next).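

Moving the chlorine, 3-chlorobenzyl to 2-chlorobenzyl, gives a 1.9-fold higher number from compound 3 to compound 4 (0.27 log units; within the scatter) in this assay, so these two placements cannot be told apart here. The large drop seen with 3-chlorophenyl is therefore not tied to that one placement: 2-chlorophenyl in place of methyl gives a 7.5-fold lower number from compound 2 to compound 4 (0.87 log units; beyond the scatter) and 2-chlorophenyl in place of hydrogen gives an 11-fold lower number from compound 1 to compound 4 (1.05 log units; beyond the scatter), both beyond the scatter. Nothing available offers an explanation for these numbers.

As far as these compounds go, it remains open whether the chlorine contributes at all or the phenyl ring alone accounts for these steps, a question that a plain benzyl group at this place would address. From the compounds shown here alone, it is also open how a longer chain ending in phenyl, or a chain ending in an amine, would behave here.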